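Iodo in Place of Nitro: Expecting Compound 4

This account rests on a few compounds, and the source may have more. Where it says the series, first, only, none or still open, it means among the compounds named here.

The measured compounds, each in an ADME assay on HUVEC cells (Homo sapiens) for cytotoxicity, read by MTT assay, with a stated time of 24 h; a lower number here means a stronger inhibitor, a higher number a weaker inhibitor:
- compound 1 `C=C1CC[C@H]2C(C)(C)CCC[C@]2(C)[C@H]1CCC(C)CC(=O)O` gives > 200000 nM.
- compound 2 `C=C1CC[C@H]2C(C)(C)CCC[C@]2(C)[C@H]1CCC(C)CC(=O)OC` gives > 200000 nM.
- compound 3 `CC(CC[C@H]1/C(=C/c2ccc([N+](=O)[O-])cc2)CC[C@H]2C(C)(C)CCC[C@]12C)CC(=O)O` gives > 200000 nM.

For compound 3 this value is only a limit of the assay, not a number. The same holds for compound 1. The same holds for compound 2. Compound 3 thus stands at the limit described in the limit of > 200000 nM in this assay, at which 3 of the 3 values shown sit, with no number to place it above or below its companions. Within the data shown here, the one measured step, a step that the two limits leave unreadable from compound 1 to compound 2, is likewise unreadable, since two limits leave its size hidden.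

Compound 4 `CC(CC[C@H]1/C(=C/c2ccc(I)cc2)CC[C@H]2C(C)(C)CCC[C@]12C)CC(=O)O` differs from compound 3 by iodo in place of nitro on an aromatic carbon. Among the measured compounds shown here, no measured step bears on this change; the single recorded step is of another kind and unreadable in any case. With every shown value sitting at the limit, no step beyond the scatter is expected in either direction. Compound 4 is therefore estimated at 250000 nM, between 100000 nM and 600000 nM, most likely reported again only as a limit, which corresponds to an expected step that the limit leaves unreadable from compound 3 to compound 4.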

Compound 4, half-maximal inhibitory concentration: 194000 nM
Estimate against measurement, compound 4: 1.3-fold (0.11 log units) above, and the stated range covers the measured number.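

In this assay compound 4 gives 194000 nM, the only value among the four compounds shown that is a number rather than a limit. Iodo in place of nitro on this aromatic carbon gives an at least 1.0-fold lower number from compound 3 to compound 4 (0.01 log units; that floor lies within the scatter), so the change is not shown to move the result beyond the scatter. The true size of this step stays hidden because compound 3 holds only a limit: the limit of > 200000 nM in this assay, at which 3 of the 4 values shown sit.

The compounds shown leave open how an amine, a bromo group or a methoxy group on the same aromatic carbon would read in this assay. They also leave open whether a methyl ester in place of the carboxylic acid of compound 4 would still give a number there.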